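Diaryl urea series: moving the trifluoromethyl group

The source may hold more compounds than are shown below. What is called first, only, known or untested is meant among the compounds shown, and "the series" means these compounds.

compound 1 `COc1cc2cc(Oc3ccc(NC(=O)Nc4ccccc4)cc3)c(C)nc2cc1OC`: 88.7%
compound 2 `COc1cc2cc(Oc3ccc(NC(=O)Nc4ccc(C(F)(F)F)cc4)cc3)c(C)nc2cc1OC`: 71.4%

In a functional assay on DU-145 cells (Homo sapiens) for inhibition, read by sulforhodamine B assay, with a stated time of 48 h, tested at 10 uM (a higher number here means a weaker effect of the compound at the concentration tested, a lower number a stronger effect), compound 2 gives 71.4%, the lower of the two numbers; compound 1 gives 88.7%. For the measured compounds named here, the single measured step is a number 17.3 percentage points lower from compound 1 to compound 2 (beyond the scatter), beyond the scatter.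

Compound 3 `COc1cc2cc(Oc3ccc(NC(=O)Nc4cccc(C(F)(F)F)c4)cc3)c(C)nc2cc1OC` differs from compound 2 by 3-(trifluoromethyl)phenyl in place of 4-(trifluoromethyl)phenyl on an amide-type nitrogen. No measured step bears on shifting the trifluoromethyl group to another position; the one step shown only concerns its presence. No step beyond the scatter is therefore expected, and the estimated step is a number 0.6 percentage points higher from compound 2 to compound 3 (within the scatter). Compound 3 is estimated at 72%, with a range from 55% to 90%.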

Compound 3, a percentage reported as activity, at one concentration (the size of the read-out at that concentration, not a potency): 26.7%
For compound 3 the middle estimate is 45.3 percentage points above the measured one, outside the stated range (below it).
By their numbers in this assay, from the lowest: compound 3; then compound 2; then compound 1.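

In this assay, the place of the trifluoromethyl group on the phenyl ring matters, not only its presence: 3-(trifluoromethyl)phenyl in place of 4-(trifluoromethyl)phenyl gives a number 44.7 percentage points lower from compound 2 to compound 3 (beyond the scatter), with the same atoms joined differently. Set against the plain phenyl, the 3-(trifluoromethyl)phenyl group gives a number 62 percentage points lower from compound 1 to compound 3 (beyond the scatter), so compound 3 has the strongest effect of the three. No evidence is available to explain this dependence on position.

From the compounds shown here alone, whether the effect belongs to trifluoromethyl itself or would also appear with 3-chlorophenyl or 3-cyanophenyl remains open.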